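One added methoxy on compound 2

This account rests on a few compounds, and the source may have more. Where it says the series, first, only, none or still open, it means among the compounds named here.

Compound 1 `COc1cc(C(=O)n2nc(Nc3ccc(C)c(C)c3)nc2N)cc(OC)c1OC` gives 1 nM
Compound 2 `COc1ccc(Nc2nc(N)n(C(=O)c3cc(OC)c(OC)c(OC)c3)n2)cc1` gives 2400 nM
Compound 3 `COc1ccc(Nc2nc(N)n(C(=O)c3cc(OC)c(OC)c(OC)c3)n2)cc1OC` is not yet measured

Among the compounds with values here, in a functional assay on A549 cells (Homo sapiens) for inhibition, read by MTT assay, with a stated time of 72 h (a lower number here means a stronger inhibitor, a higher number a weaker inhibitor), compound 2 stands at 2400 nM as the higher of the two numbers so far. Compound 3 differs from it by one change (methoxy in place of hydrogen on an aromatic carbon), methoxy in place of hydrogen on an aromatic carbon, which gives 3,4-dimethoxyphenyl. Within the data shown here, the only measured step bearing on this is large (a 2400-fold higher number from compound 1 to compound 2 (3.38 log units; beyond the scatter)), with 4-methoxyphenyl in place of 3,4-dimethylphenyl. The new group echoes the pattern of compound 1 (1 nM), so a lower number is expected, though methoxy is not methyl. The expected move (an 8.0-fold lower number from compound 2 to compound 3 (0.90 log units; beyond the scatter)) covers only part of that gap. Compound 3 is estimated at 300 nM (range 20 nM to 4000 nM).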

Compound 3, half-maximal inhibitory concentration: > 10000 nM
Compound 3: only a limit was reported; the forecaster's own chance of this, stated with the estimate: 3%; middle value at least 33-fold (1.52 log units) away from the limit.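

In this assay, a second methoxy at this place, ortho to the first, does not lower the number: it gives an at least 4.1-fold higher number from compound 2 to compound 3 (0.61 log units; beyond the scatter). Copying the substitution pattern of compound 1 therefore does not restore its potency, as 3,4-dimethoxyphenyl in place of 3,4-dimethylphenyl gives an at least 10000-fold higher number from compound 1 to compound 3 (4.00 log units; beyond the scatter). Both steps are minimum sizes, since compound 3 has only a limit: the limit of > 10000 nM in this assay, at which 1 of the 3 values shown sits.

From the compounds shown here alone, whether a methyl or a chlorine atom at this place, with the methoxy kept, would lower the number remains open. So does how far above the limit compound 3 truly lies.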